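The source may report more compounds than this note shows. Statements on the series, on what has been measured and on what is new or still open speak of the compounds shown alone.

Within the series built on the shared core, compound 1 `COc1cc(OC)c(-c2coc3cc(OCC(=O)c4cccc(C(F)(F)F)c4)ccc3c2=O)cc1OC`, compound 2 `COc1cc(OC)c(-c2coc3cc(OCc4ccccc4F)ccc3c2=O)cc1OC` and compound 3 `COc1cc(OC)c(-c2coc3cc(OCc4ccccc4C)ccc3c2=O)cc1OC` have been measured in a functional assay on A-375 cells (Homo sapiens) for antiproliferative activity, read by MTT assay, with a stated time of 24 h; a higher number here means a weaker inhibitor, a lower number a stronger inhibitor. Compound 1 reaches only a limit of the assay, > 10000 nM. Compound 2 gives 2100 nM, and compound 3 gives 1360 nM, the lowest of the two numbers; the two sit within the scatter of each other, a 1.5-fold lower number from compound 2 to compound 3 (0.19 log units; within the scatter). The unmeasured compound 4 `COc1cc(OC)c(-c2coc3cc(OCc4ccc(C(F)(F)F)cc4)ccc3c2=O)cc1OC` differs from compound 3 by 4-(trifluoromethyl)phenyl in place of 2-methylphenyl on a saturated chain carbon bound to an oxygen on an aromatic ring. Of the measured steps, only an at least 7.3-fold lower number from compound 1 to compound 3 (0.86 log units; beyond the scatter) involves a trifluoromethyl-bearing ring, and there the ring is joined through a carbonyl, so it bears only loosely on the present change. A modest rise in this assay is expected for compound 4, a 2.6-fold higher number from compound 3 to compound 4 (0.41 log units; beyond the scatter). Compound 4 is estimated at 3500 nM, within 1200 nM to 10000 nM.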

Compound 4, half-maximal inhibitory concentration: 2280 nM
Compound 4: the middle estimate sits 1.5-fold (0.19 log units) above what was measured; low and high end bracket the measured number.
By their numbers in this assay, from the lowest: compounds 3, 2 and 4 (each within the scatter of the next). At a limit, above all of these: compound 1.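

In this assay, 4-(trifluoromethyl)phenyl on this saturated chain carbon is not separated from the two smaller-substituted rings: a 1.7-fold higher number from compound 3 to compound 4 (0.22 log units; within the scatter), and a 1.1-fold higher number from compound 2 to compound 4 (0.04 log units; within the scatter). At this place, therefore, the three rings shown cannot be ranked, and the trifluoromethyl group is tolerated on a ring joined without a carbonyl. The step from the carbonyl-joined ring, an at least 4.3-fold lower number from compound 1 to compound 4 (0.64 log units; beyond the scatter), lies beyond the scatter but rests on a limit and gives only a bound: the limit of > 10000 nM in this assay, at which 1 of the 4 values shown sits.

As far as these compounds go, whether an amine or a carboxylic acid on this ring would move the number beyond the scatter remains open. From the compounds shown here alone, the effect of a longer chain in place of the saturated chain carbon also remains open.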